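The compounds below may be only part of what the source reports. "The series", "measured", "known", "first", "only" and "open" are said of these compounds alone.

Two compounds share one core and were measured in an assay on membranes from HeLa cells for displacement of a labelled ligand from adenosine receptor A3 (Homo sapiens), read by scintillation counting, with a stated time of 180 min, tested at 1 uM; a lower number here means less inhibition, a higher number more inhibition at the concentration tested (going by the name of the read-out). Compound 1 `COC(=O)C1=C(C)NC(=S)NC1c1ccoc1` gives 3% in this assay, the lowest of the two numbers shown. Compound 2 `CC1=C(C(=O)OCc2ccccc2)C(c2ccoc2)NC(=S)N1` gives 20%. Within the data shown here, the single measured step, a number 17 percentage points higher from compound 1 to compound 2 (beyond the scatter), comes with a change on the ester side of the molecule: phenyl in place of hydrogen on a saturated chain carbon bound to an oxygen next to a carbonyl group.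

Compound 3 `COC(=O)C1=C(C)NC(=S)NC1c1cccs1` is not yet measured. It differs from compound 1 in another place: thiophen-2-yl in place of furan-3-yl on a saturated ring carbon. This change leaves the ester untouched and swaps one five-membered aromatic ring for another on the saturated ring carbon of the core. Among the measured compounds shown here, no measured step covers this kind of swap, so the one known step gives no direct guide; the only firm fact is the low starting point of compound 1. On that basis compound 3 is expected to stay close to compound 1, with an estimated step of a number 5 percentage points higher from compound 1 to compound 3 (within the scatter), not beyond the scatter. The estimate for compound 3 in this assay is 8%, with a range from 0% to 22%.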

Compound 3, a percentage reported as inhibition, at one concentration (the size of the read-out at that concentration, not a potency): 1%
Compound 3: the middle estimate sits 7 percentage points above what was measured; the measured number falls inside the stated range.
By their numbers in this assay, from the lowest: compounds 3 and 1 (each within the scatter of the next); then compound 2.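

Among these compounds, exchanging furan-3-yl for thiophen-2-yl on the saturated ring carbon gives a number 2 percentage points lower from compound 1 to compound 3 (within the scatter) in this assay, the first measured change at this position of the shared core. Among the compounds shown here, this single step replaces the ring's oxygen with sulfur and also changes the attachment point named in the two groups, so it cannot show what either difference does alone; it shows only that this particular pair of five-membered aromatic rings stays within the scatter at a low level of inhibition. The only step shown that lies beyond the scatter remains the one on the ester side, a number 17 percentage points higher from compound 1 to compound 2 (beyond the scatter), and no supporting measurement is available to explain either result.

On these data alone, it remains open whether a more different group on this ring carbon, such as pyridin-3-yl or an n-butyl chain, would raise the inhibition above the low level seen for compound 1 and compound 3. As far as these compounds go, it is also open whether thiophen-2-yl would behave the same way alongside the benzyl ester of compound 2, where the starting value is higher and a fall could be seen more clearly.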